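This account rests on a few compounds, and the source may have more. Where it says the series, first, only, none or still open, it means among the compounds named here.

Measured compounds:
- Compound 1, `CCc1ccc(Nc2cc(NC(=O)Nc3cc(OC)cc(OC)c3)ncn2)cc1`: 66.2%
- Compound 2, `COc1cc(Nc2cc(NC(=O)Nc3c(Cl)cccc3Cl)ncn2)cc(OC)c1`: 73.7%
- Compound 3, `COc1ccc(OC)c(Nc2cc(NC(=O)Nc3c(Cl)cccc3Cl)ncn2)c1`: 94.1%

These three share one core and were all tested in a functional assay on HCC827 cells (Homo sapiens) for inhibition, read by MTT assay, with a stated time of 48 h, tested at 10 uM; on this read-out higher numbers stand for more inhibition at the one concentration tested (going by the name of the read-out) and lower numbers for less inhibition. Compound 1 gives the lowest of the three numbers. Compound 2 sits close to it, within the usual scatter of this kind of measurement, so the two cannot be ranked against each other. Compound 3 stands well beyond the scatter above compound 1 and is the only one of the three that clearly separates from it.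

Compound 4, `COc1cc(NC(=O)Nc2cc(Nc3ccc(OC)c(C)c3)ncn2)cc(OC)c1`, has not yet been measured. It differs from compound 1 in one place: 4-methoxy-3-methylphenyl in place of 4-ethylphenyl on a nitrogen on an aromatic ring. Within the data shown here, no pair of measured compounds differs in just one place, so there is no directly comparable step to lean on. Compound 3 carries methoxy groups on the same aryl amine and scores highest, but it also differs elsewhere, so it gives only a loose hint.

The expectation for compound 4 is therefore a modest rise at most, quite possibly nothing beyond the scatter, with an estimated step of a number 5.8 percentage points higher from compound 1 to compound 4 (within the scatter). Compound 4 is estimated at 72%, most likely between 54% and 88%.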

Compound 4, a percentage reported as inhibition, at one concentration (the size of the read-out at that concentration, not a potency): 48.3%
For compound 4 the middle estimate is 23.7 percentage points above the measured one; the measured number lies below the stated range.
By their numbers in this assay, from the lowest: compound 4; then compounds 1 and 2 (each within the scatter of the next); then compound 3.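

In this assay, among these compounds, putting 4-methoxy-3-methylphenyl in place of 4-ethylphenyl on the nitrogen gives a number 17.9 percentage points lower from compound 1 to compound 4 (beyond the scatter), the first change at a single place that can be read in this set. It shows that the group at this position matters to the read-out, and that here the group with one more heavy atom and a hydrogen-bond acceptor goes with less inhibition, although this rests on one pair of compounds tested at one concentration. Nothing measured here explains the drop, and this pair cannot say how much of it belongs to the methoxy group and how much to the methyl group.

From the compounds shown here alone, it remains open whether a ring carrying only a methoxy group or only a methyl group would behave like compound 4 or like compound 1, and how the position would respond to a plain phenyl ring, a longer chain such as butyl, or a ring bearing an amine or a carboxylic acid. Going by these compounds, it is also open whether the same swap would give a step of similar size when the other end of the molecule carries a different group.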